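Trifluoromethyl in place of hydrogen on compound 2

The source may report more compounds than this note shows. Statements on the series, on what has been measured and on what is new or still open speak of the compounds shown alone.

In an ADME assay on MDBK cells (Bos taurus) for cytotoxicity, read by MTT assay, with a stated time of 96 h (on this read-out higher numbers stand for lower toxicity in this test and lower numbers for higher toxicity in this test), compound 1 `CC(=O)c1ccc2[nH]c(-c3ccc(C(F)(F)F)cc3)nc2c1` gives > 100000 nM, which is a limit of the assay and not a number. Among the compounds with values here, compound 2 `C/C(=N\NC(N)=S)c1ccc2[nH]c(-c3ccccc3)nc2c1` gives 32000 nM, the only actual number so far. Compound 3 `C/C(=N\NC(N)=S)c1ccc2[nH]c(-c3ccc(C(F)(F)F)cc3)nc2c1` has trifluoromethyl in place of hydrogen on an aromatic carbon, para to a large group (trifluoromethyl in place of hydrogen on an aromatic carbon). Within the data shown here, no measured pair isolates this change, so no shift beyond the scatter is expected in this assay. The estimated step of a 1.1-fold higher number from compound 2 to compound 3 (0.04 log units; within the scatter) is small. For compound 3 the expected value is 35000 nM, with an estimated range of 12000 nM to 90000 nM.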

Compound 3, half-maximal cytotoxic concentration: 5000 nM
Compound 3: the middle estimate sits 7.0-fold (0.85 log units) above what was measured, outside the stated range (below it).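

In this assay there is a 6.4-fold lower number from compound 2 to compound 3 (0.81 log units; beyond the scatter) on trifluoromethyl entering at this aromatic carbon, so this position responds to the change. The group of 7 heavy atoms in place of the group of 3 heavy atoms gives an at least 20-fold lower number from compound 1 to compound 3 (1.30 log units; beyond the scatter) with trifluoromethyl kept, so in this pair the lower number goes with the larger group. For compound 1 the value is a limit of the assay and not a number: the limit of > 100000 nM in this assay, at which 1 of the 3 values shown sits.

Open, on these data alone, is whether a chlorine atom or a methoxy group on the same carbon would give a step of similar size. Also open, as far as these compounds go, is how a shorter chain on the hydrazone side would read.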